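The source may report more compounds than this note shows. Statements on the series, on what has been measured and on what is new or still open speak of the compounds shown alone.

In an ADME assay on Raji cells (Homo sapiens) for cytotoxicity, read by luminescence, with a stated time of 72 h (on this read-out higher numbers stand for an effect only at larger amounts of compound and lower numbers for an effect already at smaller amounts), two compounds on a shared core have been measured so far. Compound 1 (`CCOC(=O)c1c(-c2cccc(-c3ccccc3)c2)[nH]c2cc(OC)ccc2c1=O`) gives > 21500 nM, which is a limit of the assay and not a number. Compound 2 (`CCOC(=O)c1c(-c2cccc(-c3ccccc3)c2)[nH]c2cc(OC)c(OC)cc2c1=O`) gives > 21500 nM, which is also a limit. Compound 2 therefore has no exact position in the series, and neither compound offers a number to compare against.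

The next change leads to compound 3 (`CCOC(=O)c1c(-c2cccc(Oc3ccccc3)c2)[nH]c2cc(OC)c(OC)cc2c1=O`), with phenoxy in place of phenyl on an aromatic carbon, meta to a large group: phenoxy in place of phenyl on an aromatic carbon. For the measured compounds named here, no measured step covers this exchange. Going by the values given here, the only step available, methoxy in place of hydrogen on an aromatic carbon, is a step that the two limits leave unreadable from compound 1 to compound 2, so it gives no size to carry over. No shift in either direction beyond the scatter is therefore expected in this assay. Compound 3 is expected to behave like compound 2 because of the limit of > 21500 nM in this assay, at which 2 of the 2 values shown sit, and another limit is the likeliest report. The expected change is a step that the limit leaves unreadable from compound 2 to compound 3. For compound 3 the estimated value is 25000 nM, with an expected range of 10000 nM to 50000 nM.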

Compound 3, half-maximal effective concentration: > 21500 nM
Compound 3 was reported as a limit (the forecaster's own chance of this, stated with the estimate: 85%); the middle value is on the limit's open side.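

No new step can be read from compound 2 to compound 3 in this assay, since both are reported as limits and not as numbers. All the reports shown sit together: the limit of > 21500 nM in this assay, at which 3 of the 3 values shown sit.

The compounds shown leave open whether phenoxy in place of phenyl, or methoxy in place of hydrogen, shifts the read-out at all on the shared core.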